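A few compounds are considered here, and "the series" means these few. Any claim that something is new, unique, unknown or untested is made for them only; others in the source may bear on it.

Of the compounds shown here, three built on two closely related cores have been tested in a functional assay on MDA-MB-231 cells (Homo sapiens) for cytotoxicity, read by MTT assay, with a stated time of 72 h; a higher number here means a weaker inhibitor, a lower number a stronger inhibitor. Compound 1 `COc1ccc(/C=C2\S/C(=N\c3csc(-c4ccc(Cl)cc4)c3)NC2=O)cc1` gives 1200 nM in this assay. Compound 2 `Cc1ccc(/C=C2\S/C(=N\c3csc(-c4ccc(Cl)cc4)c3)NC2=O)cc1` carries a methyl where compound 1 carries a methoxy; in this assay compound 2 gives 900 nM. The change between them, (methoxy in place of methyl on an aromatic carbon), made a 1.3-fold higher number from compound 2 to compound 1 (0.12 log units; within the scatter). Compound 3 `Cc1ccc(/C=C2\S/C(=N\c3nc(-c4ccc(Cl)cc4)cs3)NC2=O)cc1` keeps the side groups of compound 2 on a different core; the difference between the two cores is not broken down here. In this assay compound 3 gives 800 nM, a number within the scatter of both others. Compound 4 `COc1ccc(/C=C2\S/C(=N\c3nc(-c4ccc(Cl)cc4)cs3)NC2=O)cc1` is not yet measured; it differs from compound 3 by methoxy in place of methyl on an aromatic carbon, the same change as from compound 2 to compound 1, at the same place. The step is expected to be small, a 1.3-fold higher number from compound 3 to compound 4 (0.10 log units; within the scatter), because the like step gave a 1.3-fold higher number from compound 2 to compound 1 (0.12 log units; within the scatter). Compound 4 is therefore expected to give 1000 nM, estimated between 600 nM and 1700 nM.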

Compound 4, half-maximal inhibitory concentration: 300 nM
Compound 4: the middle estimate sits 3.3-fold (0.52 log units) above what was measured; measured number below the stated range.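

On the core of compound 3, putting methoxy in place of methyl gave a 2.7-fold lower number from compound 3 to compound 4 (0.43 log units; beyond the scatter) in this assay. The same change therefore did not carry over unchanged from one core to the other: the same change on two cores in this assay, a 1.3-fold higher number (0.12 log units; within the scatter) from compound 2 to compound 1 and a 2.7-fold lower number (0.43 log units; beyond the scatter) from compound 3 to compound 4, 3.6-fold (0.55 log units) apart, beyond the scatter of two such steps

This rests on a single pair on each core, so it shows that the size of the step depended on the core in these four compounds, but it does not show why, or what the change would do on any further core. The compounds shown leave open how other groups in this place on the ring, such as ethoxy, hydroxyl or dimethylamino, would behave on each core. They also leave open whether the gap between the two steps would appear in other cell lines.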